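Moving the methyl on the aryl amine of compound 2

The source may report more compounds than this note shows. Statements on the series, on what has been measured and on what is new or still open speak of the compounds shown alone.

Compound 1 `Cc1cccc(N(C)CC2CCC/C(=C\c3ccccc3)C2=O)c1`: 76.7%
Compound 2 `Cc1ccc(N(C)CC2CCC/C(=C\c3ccc(S(C)(=O)=O)cc3)C2=O)cc1`: 84.5%

Among the measured compounds shown here, in a functional assay on the whole organism (strain Kunming) for inhibition, with Mus musculus as the target, in the writhing test, with stated times of 1 h and 15 min, at a dose of 200 mg/kg by the oral route (on this read-out higher numbers stand for more inhibition at the one dose given (going by the name of the read-out) and lower numbers for less inhibition), compound 2 gives 84.5%, and its only neighbour for comparison, compound 1, sits within the scatter of it, so the two cannot be ranked. Compound 3 `Cc1cccc(N(C)CC2CCC/C(=C\c3ccc(S(C)(=O)=O)cc3)C2=O)c1` differs from compound 2 in one place: 3-methylphenyl in place of 4-methylphenyl on an amine nitrogen. For the measured compounds named here, no measured pair shows this change alone, so the direction is open. Compound 3 is expected to stay near compound 2, with a step of a number 4.5 percentage points lower from compound 2 to compound 3 (within the scatter) in this assay not beyond the scatter. Compound 3 is estimated at 80%, within 65% to 92%.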

Compound 3, a percentage reported as inhibition, in the whole organism at one dose (the size of the read-out at that dose, not a potency): 72.8%
The estimate for compound 3 lay 7.2 percentage points above the measured number, within the range that was stated.
By their numbers in this assay, from the lowest: compounds 3, 1 and 2 (each within the scatter of the next, the first and the last beyond it).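

In this assay, the place of the methyl on the aryl amine proves to matter: 3-methylphenyl in place of 4-methylphenyl gives a number 11.7 percentage points lower from compound 2 to compound 3 (beyond the scatter) as a modest step. With 3-methylphenyl held, methylsulfonyl in place of hydrogen on an aromatic carbon gives a number 3.9 percentage points lower from compound 1 to compound 3 (within the scatter) and so cannot be separated from the scatter. No measurement on hand accounts for the step between the two methylphenyl groups. The compounds shown leave open how 4-methoxyphenyl or 4-chlorophenyl on that nitrogen would read, and how methylsulfonyl would read with 4-methylphenyl in place.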